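Growth inhibition notes: from compound 2 to compound 3

The source may hold more compounds than are shown below. What is called first, only, known or untested is meant among the compounds shown, and "the series" means these compounds.

compound 1 `O=S(=O)(/C=C/c1ccc(Br)cc1)Cc1ccc(Nc2ncnc3ccccc23)cc1` (38000 nM)
compound 2 `O=S(=O)(/C=C/c1ccc(Br)cc1)Cc1ccc(Nc2ncnc3ccc(Br)cc23)cc1` (2000 nM)
compound 3 `O=S(=O)(/C=C/c1ccc(F)cc1F)Cc1ccc(Nc2ncnc3ccc(Br)cc23)cc1` (not yet measured)

In a functional assay on OVCAR-8 cells (Homo sapiens) (on this read-out higher numbers stand for weaker inhibition of growth and lower numbers for stronger inhibition of growth), compound 2 holds the lower of the two measured numbers at 2000 nM and compound 1 stands at 38000 nM on this scale. Among the compounds with values here, the single measured step is a 19-fold lower number from compound 1 to compound 2 (1.28 log units; beyond the scatter) (large and beyond the scatter) for bromo in place of hydrogen on an aromatic carbon.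

Compound 3 keeps that bromo on the shared core. It changes elsewhere, on a double-bonded chain carbon bound to a double-bonded chain carbon, with 2,4-difluorophenyl in place of 4-bromophenyl (2,4-difluorophenyl in place of 4-bromophenyl on a double-bonded chain carbon bound to a double-bonded chain carbon). Within the data shown here, no measured step covers a change at this place, and the one step available concerns another part of the molecule, so its size does not carry over. In this assay no step beyond the scatter is therefore expected, though the uncertainty is wide. The expected change is a 1.3-fold higher number from compound 2 to compound 3 (0.10 log units; within the scatter) in this estimate. Compound 3 is expected at 2500 nM with an estimated range of 800 nM to 8000 nM in this assay for now.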

Compound 3, concentration for 50% growth inhibition: 100000 nM
For compound 3 the middle estimate is 40-fold (1.60 log units) below the measured one; measured number above the stated range.
By their numbers in this assay, from the lowest: compound 2; then compound 1; then compound 3.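

In this assay the group on a double-bonded chain carbon bound to a double-bonded chain carbon proves to be a sensitive place in this series: 2,4-difluorophenyl in place of 4-bromophenyl gives a 50-fold higher number from compound 2 to compound 3 (1.70 log units; beyond the scatter) and so a large step beyond the scatter. Growth inhibition here therefore depends on this end of the molecule as well as on the bromo on the shared core, and keeping that bromo does not hold the number of compound 2 at 2000 nM once 4-bromophenyl leaves. The step removes one bromine and brings in two fluorine atoms at once, so it cannot be assigned to either part of the exchange, and no measurement at hand accounts for its size.

Still open, as far as these compounds go, is whether an unsubstituted phenyl, a chlorophenyl or a monofluorophenyl at this place would stay close to compound 2 or fall towards compound 3. Also open, from the compounds shown here alone, is how this place responds to a group of another kind, such as an amine or a carboxylic acid on the phenyl ring.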